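The source may report more compounds than this note shows. Statements on the series, on what has been measured and on what is new or still open speak of the compounds shown alone.

In a functional assay on the whole organism (strain Swiss albino) with Mus musculus as the target, with a stated time of 4 h (a lower number here means that less compound is needed, a higher number that more compound is needed for the effect), three compounds have been measured so far:

compound 1 `C=C(C)[C@@H]1CC=C(C)/C(=N/NC(=O)Nc2nnc(-c3ccc([N+](=O)[O-])cc3)o2)C1`: 300 mg/kg
compound 2 `C=C(C)[C@@H]1CC=C(C)/C(=N/NC(=O)Nc2nnc(-c3ccc(O)cc3)o2)C1`: 300 mg/kg
compound 3 `CC(C)=CC/C=C(/C)C/C=N/NC(=O)Nc1nnc(-c2ccc([N+](=O)[O-])cc2)o1`: 300 mg/kg

Compound 3 stands level with compound 1 and with compound 2; all three values lie within the usual scatter of one another, so none can be set apart. Compound 4 `CC(C)=CC/C=C(/C)C/C=N/NC(=O)Nc1nnc(-c2ccc(C)cc2)o1` is the next step from compound 3: methyl in place of nitro on an aromatic carbon. Within the data shown here, the one measured step that bears on this change is the one at the same aromatic carbon, no change at the digits printed from compound 1 to compound 2 (within the scatter), which stayed within the scatter. Compound 4 is therefore expected to show no step beyond the scatter, no change at the digits printed from compound 3 to compound 4 (within the scatter). The estimate for compound 4 in this assay is 300 mg/kg, with a range from 150 mg/kg to 600 mg/kg.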

Compound 4, minimum effective dose: 300 mg/kg
Estimate against measurement, compound 4: no gap at the digits printed; low and high end bracket the measured number.
By their numbers in this assay, from the lowest: compounds 1, 2, 3 and 4 (each within the scatter of the next).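

In this assay the change from 4-nitrophenyl to 4-methylphenyl gives no change at the digits printed from compound 3 to compound 4 (within the scatter), so a second group now stands in place of nitro on this aromatic carbon, on a different remainder of the molecule from the hydroxy step, which gave no change at the digits printed from compound 1 to compound 2 (within the scatter). Both replacements of nitro stay within the scatter, and no compound shown goes against this. No measured finding accounts for this flat result. As far as these compounds go, whether an amine or a carboxylic acid on this aromatic carbon would shift the minimum effective dose remains open.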